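Chain shortening on a piperazinyl-pyridine anticonvulsant series

This account rests on a few compounds, and the source may have more. Where it says the series, first, only, none or still open, it means among the compounds named here.

Measured compounds:
- compound 1, `CCCCCCCc1cccc(N2CCNCC2)n1`: 10 mg/kg
- compound 2, `CCCCc1cccc(N2CCNCC2)n1`: 30 mg/kg
- compound 3, `CCCCCCCCc1cccc(N2CCNCC2)n1`: 10 mg/kg

All three numbers come from a functional assay on the whole organism with Mus musculus as the target, in the maximal electroshock model, with a stated time of 120 min; on this read-out lower numbers stand for an effect already at smaller amounts and higher numbers for an effect only at larger amounts of compound. Compound 1 and compound 3 share the lower pair of values; between them the difference methyl in place of hydrogen on a saturated chain carbon, seven bonds along the chain from an aromatic carbon leaves the read-out unchanged, no change at the digits printed from compound 1 to compound 3 (within the scatter). Compound 2 stands apart: the change hydrogen in place of propyl on a saturated chain carbon, four bonds along the chain from an aromatic carbon gives a 3.0-fold higher number from compound 1 to compound 2 (0.48 log units; beyond the scatter), a modest step beyond the scatter.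

Compound 4, `CCCCCc1cccc(N2CCNCC2)n1`, is not yet measured. It differs from compound 3 by hydrogen in place of propyl on a saturated chain carbon, five bonds along the chain from an aromatic carbon. Among the measured compounds shown here, this is the same kind of change as the one from compound 1 to compound 2, but not the same: there the place is four bonds along the chain from an aromatic carbon, here it is five bonds along. The cores of the two pairs differ by methyl in place of hydrogen on a saturated chain carbon, seven bonds along the chain from an aromatic carbon, which on its own moved nothing.

For compound 4 in this assay a step similar in size to the earlier one is expected, a 2.5-fold higher number from compound 3 to compound 4 (0.40 log units; beyond the scatter), resting on compound 1 to compound 2 showing a 3.0-fold higher number from compound 1 to compound 2 (0.48 log units; beyond the scatter) for the same kind of loss of propyl. Compound 4 is therefore estimated at 25 mg/kg, with a range from 10 mg/kg to 60 mg/kg.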

Compound 4, minimum effective dose: 10 mg/kg
For compound 4 the middle estimate is 2.5-fold (0.40 log units) above the measured one; the range from low to high includes it.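

In this assay the loss of propyl gives no change at the digits printed from compound 3 to compound 4 (within the scatter), so this change does not carry unchanged from one core to the other: the same change on two cores in this assay, a 3.0-fold higher number (0.48 log units; beyond the scatter) from compound 1 to compound 2 and no change at the digits printed (within the scatter) from compound 3 to compound 4, 3.0-fold (0.48 log units) apart, beyond the scatter of two such steps
The added methyl behaves the same way, giving a 3.0-fold lower number from compound 2 to compound 4 (0.48 log units; beyond the scatter): the same change on two cores in this assay, no change at the digits printed (within the scatter) from compound 1 to compound 3 and a 3.0-fold lower number (0.48 log units; beyond the scatter) from compound 2 to compound 4, 3.0-fold (0.48 log units) apart, beyond the scatter of two such steps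
With no change at the digits printed from compound 1 to compound 4 (within the scatter) as well, compound 2 alone stands apart from the other three compounds, which shows that the effect of these chain changes depends on the core they start from, but with so few compounds it does not show why, nor does it fix a chain length at which the read-out shifts.

As far as these compounds go, whether the read-out stays level with a chain longer than that of compound 3, and where a chain shorter than the butyl of compound 2, such as ethyl or methyl, would fall, remains open. A hydroxyl or an amine at the end of the chain also lies outside the compounds shown.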